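Shortening and saturating the linoleoyl chain of a tetrahydropyranylmethyl ester

This account rests on a few compounds, and the source may have more. Where it says the series, first, only, none or still open, it means among the compounds named here.

Compound 1 `CCCCCCCC/C=C\CCCCCCCC(=O)OCC1CCCCO1`: 29000 nM
Compound 2 `CC/C=C\C/C=C\C/C=C\CCCCCCCC(=O)OCC1CCCCO1`: 19000 nM
Compound 3 `CCCCC/C=C\C/C=C\CCCCCCCC(=O)OCC1CCCCO1`: 7500 nM

In an assay on membranes from cerebellum for inhibition of Fatty-acid amide hydrolase 1 (Rattus norvegicus) (on this read-out lower numbers stand for stronger inhibition and higher numbers for weaker inhibition), compound 3 gives the lowest number of the three, with the steps of a 3.9-fold lower number from compound 1 to compound 3 (0.59 log units; beyond the scatter) and a 2.5-fold lower number from compound 2 to compound 3 (0.40 log units; beyond the scatter) both beyond the scatter. Compound 4 `CCCCCC/C=C\CCCCCCCC(=O)OCC1CCCCO1` differs from compound 3 by pentyl in place of hept-1-en-1-yl on a saturated chain carbon bound to a double-bonded chain carbon. Going by the values given here, two measured steps bear on removing a chain double bond, and they point in opposite directions: the step of a 3.9-fold lower number from compound 1 to compound 3 (0.59 log units; beyond the scatter) shows that adding one lowered the number, whereas the step of a 2.5-fold lower number from compound 2 to compound 3 (0.40 log units; beyond the scatter) shows that removing one also lowered it. Among the compounds with values here, no measured step covers a shorter chain. The expectation is therefore a modest rise in the number, a 2.0-fold higher number from compound 3 to compound 4 (0.30 log units; within the scatter), with wide uncertainty. Compound 4 is estimated at 15000 nM, between 5000 nM and 45000 nM.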

Compound 4, half-maximal inhibitory concentration: 10000 nM
Compound 4: the middle estimate sits 1.5-fold (0.18 log units) above what was measured, and the stated range covers the measured number.
By their numbers in this assay, from the lowest: compounds 3, 4, 2 and 1 (each within the scatter of the next, the first and the last beyond it).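

With pentyl at this place, the steps of a 1.3-fold higher number from compound 3 to compound 4 (0.12 log units; within the scatter) and a 1.9-fold lower number from compound 2 to compound 4 (0.28 log units; within the scatter) in this assay both stay within the scatter. Going by these compounds alone, the one step beyond the scatter is the first measured shortening of the chain: hydrogen in place of ethyl, with the single double bond kept, gives a 2.9-fold lower number from compound 1 to compound 4 (0.46 log units; beyond the scatter) in this series. So chain length matters here, not only the count of double bonds.

A still shorter chain, or a carboxylic acid in place of the ester, remains an open question. No evidence is available to explain these shifts.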